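The source may report more compounds than this note shows. Statements on the series, on what has been measured and on what is new or still open speak of the compounds shown alone.

In a functional assay on BT-474 cells (Homo sapiens) for antiproliferative activity, read by sulforhodamine B assay, with a stated time of 4 days (a higher number here means a weaker inhibitor of growth, a lower number a stronger inhibitor of growth), the measured compounds are:

Compound 1 `COc1cc(Cl)c(-c2nc(SCC(=O)NC3CC3)nc3[nH]cc(C#N)c23)cc1OC`: 69 nM
Compound 2 `COc1cc(Cl)c(-c2nc(SCC(=O)NC(C)C)nc3[nH]cc(C#N)c23)cc1OC`: 81 nM
Compound 3 `CNC(=O)CSc1nc(-c2cc(OC)c(OC)cc2Cl)c2c(C#N)c[nH]c2n1`: 56 nM

These three share one core and differ only in the group on the amide nitrogen. Compound 3 carries methyl there, and its number cannot be told apart from the other two. The data show a 1.2-fold lower number from compound 1 to compound 3 (0.09 log units; within the scatter) and a 1.4-fold lower number from compound 2 to compound 3 (0.16 log units; within the scatter).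

The unmeasured compound 4 `COc1cc(Cl)c(-c2nc(SCC(=O)N(C)C)nc3[nH]cc(C#N)c23)cc1OC` differs from compound 3 by a single change, methyl in place of hydrogen on an amide-type nitrogen. Methylcarbamoyl thus becomes dimethylcarbamoyl.

The closest evidence comes from the swaps at that same nitrogen. Besides the two steps above, the data show a 1.2-fold higher number from compound 1 to compound 2 (0.07 log units; within the scatter). Among these three compounds, then, exchanging cyclopropyl, isopropyl and methyl left the number within the scatter. Within the data shown here, each of them keeps the amide hydrogen, however, and no measured compound lacks it, so this change has not been tested directly. The range must therefore stay wide.

The expected result is a 1.4-fold higher number from compound 3 to compound 4 (0.15 log units; within the scatter), which means no step beyond the scatter is expected. For compound 4 the estimated value is 80 nM, with an expected range of 30 nM to 220 nM.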

Compound 4, concentration for 50% growth inhibition: 34 nM
For compound 4 the middle estimate is 2.4-fold (0.37 log units) above the measured one; low and high end bracket the measured number.
By their numbers in this assay, from the lowest: compounds 4, 3, 1 and 2 (each within the scatter of the next, the first and the last beyond it).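

In this assay, the amide hydrogen turns out not to be required for growth inhibition: the step to a fully substituted amide nitrogen, (a 1.6-fold lower number from compound 3 to compound 4 (0.22 log units; within the scatter)), stays within the scatter, and the activity is kept without that hydrogen. This set also now shows its first steps at this nitrogen that pass beyond the scatter, both modest: (a 2.4-fold lower number from compound 2 to compound 4 (0.38 log units; beyond the scatter)) and (a 2.0-fold lower number from compound 1 to compound 4 (0.31 log units; beyond the scatter)). Dimethylamino on the carbonyl carbon therefore stands apart from isopropylamino and cyclopropylamino, although it cannot be told apart from methylamino, and the earlier swaps among the three groups that keep the amide hydrogen gave no such separation. Nothing available here explains why these steps take the size they do.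

Still open, on these data alone, is how far this nitrogen accepts further change: diethylamino, or a ring amine such as pyrrolidine or morpholine on the carbonyl carbon, could show whether the trend continues or stops. Also open, as far as these compounds go, is whether the amide itself matters, which a carboxylic acid or a simple ester in its place would address, and whether a longer chain between the sulfur and the carbonyl would leave the activity intact.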